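The compounds below may be only part of what the source reports. "The series", "measured", "known", "first", "only" and "open" are said of these compounds alone.

Compound 1 `CN(C)C(=O)CN1CCC(c2cc3c(-c4ccc(=O)n(C)c4)ccnc3[nH]2)CC1` is the starting point of this comparison. In an ADME assay on cells (Hepatocyte, Rattus norvegicus) for metabolic stability (on this read-out higher numbers stand for fast clearance and lower numbers for slow clearance), compound 1 gives only a limit of the assay, < 1 uL/min, so its true number is not known, and this is the case described by the limit of < 1 uL/min in this assay, at which 1 of the 3 values shown sits. Compound 2 `CN(C)C(=O)CN1CCC(c2cc3c(-c4ccc(=O)n(C5CCOCC5)c4)ccnc3[nH]2)CC1` gives 2.3 uL/min in this assay. Compound 3 `CN(C)C(=O)CN1CCC(c2cc3c(-c4ccc(=O)n(CCC5CCOCC5)c4)ccnc3[nH]2)CC1` gives 14 uL/min in this assay. The measured steps all change the group on the aromatic nitrogen: an at least 2.3-fold higher number from compound 1 to compound 2 (0.36 log units; beyond the scatter), an at least 14-fold higher number from compound 1 to compound 3 (1.14 log units; beyond the scatter) and a 6.1-fold higher number from compound 2 to compound 3 (0.78 log units; beyond the scatter).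

Compound 4 `COc1cc(=O)n(C)cc1-c1ccnc2[nH]c(C3CCN(CC(=O)N(C)C)CC3)cc12` differs from compound 1 in another way: methoxy in place of hydrogen on an aromatic carbon. Within the data shown here, none of the measured steps touches that position, so they give no direct guide to the size or direction of this change; they show only that the shared core can stay at the limit or rise well above it. Because compound 1 sits at < 1 uL/min, only a small rise beyond the scatter, or none, is expected here. The expected step is an at least 1.2-fold higher number from compound 1 to compound 4 (0.07 log units; that floor lies within the scatter). Compound 4 is therefore estimated at 1.2 uL/min, in a range from 0.5 uL/min to 3 uL/min.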

Compound 4, intrinsic clearance in a liver preparation (reported as CLH), per the amount of preparation that the assay uses: < 1 uL/min
Compound 4: no number, only a limit; the forecaster's own chance of this, stated with the estimate: 45%; middle value at least 1.2-fold (0.07 log units) from the limit.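

Among these compounds, compound 1 and compound 4 both give only a limit in this assay, not a number, so no step between them can be read: the limit of < 1 uL/min in this assay, at which 2 of the 4 values shown sit. The compounds shown leave open whether methoxy in place of hydrogen on that aromatic carbon changes clearance at all, and in which direction.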